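Removing a Fluorine from an Aryl Carbamate

The source may report more compounds than this note shows. Statements on the series, on what has been measured and on what is new or still open speak of the compounds shown alone.

Three compounds share a core carrying a carbamate linked to an aromatic ring. Compound 1 `C=C1C(=O)OC[C@@H]1CCOC(=O)Nc1ccc(F)cc1F` gives 700 nM in a functional assay on RAW264.7 cells (Mus musculus) for inhibition, with a stated time of 30 min; on this read-out lower numbers stand for stronger inhibition and higher numbers for weaker inhibition. Compound 2 `C=C1C(=O)OC[C@H]1CCOC(=O)Nc1ccccc1F` gives 350 nM in this assay, and compound 3 `C=C1C(=O)OC[C@@H]1CCOC(=O)Nc1ccccc1F` gives 690 nM. The difference between the cores of compound 1 and compound 2 is not broken down here. Compound 2 and compound 3 are tied by the fact that compounds 2 and 3 differ only in the configuration as drawn, and the step of a 2.0-fold higher number from compound 2 to compound 3 (0.29 log units; within the scatter) is small. The change hydrogen in place of fluoro on an aromatic carbon produced a 1.0-fold lower number from compound 1 to compound 3 (0.01 log units; within the scatter). Compound 4 `C=C1C(=O)OC[C@H]1CCOC(=O)Nc1ccccc1` is not yet measured; it arises from compound 2 through (hydrogen in place of fluoro on an aromatic carbon), the same kind of change, though here the place is ortho to a large group rather than meta to a fluoro group and para to a large group. Because a 1.0-fold lower number from compound 1 to compound 3 (0.01 log units; within the scatter) lies within the scatter, compound 4 is expected to give 450 nM in this assay, between 200 nM and 1100 nM. That corresponds to an expected step of a 1.3-fold higher number from compound 2 to compound 4 (0.11 log units; within the scatter).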

Compound 4, half-maximal inhibitory concentration: 390 nM
Compound 4: the middle estimate sits 1.2-fold (0.06 log units) above what was measured; low and high end bracket the measured number.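

Exchanging the fluoro group for hydrogen on the core of compound 2 gives a 1.1-fold higher number from compound 2 to compound 4 (0.05 log units; within the scatter) in this assay. Set beside the earlier case, the change shows no dependence on the core in these two examples: the same change on two cores in this assay, a 1.0-fold lower number (0.01 log units; within the scatter) from compound 1 to compound 3 and a 1.1-fold higher number (0.05 log units; within the scatter) from compound 2 to compound 4, 1.1-fold (0.05 log units) apart, within the scatter of two such steps. Going by these compounds alone, this shows only that removing this fluoro group had no effect large enough to stand out from the scatter in either pair; it does not show that a smaller effect is absent, or that the same would hold on other cores or at other places on the ring.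

The compounds shown leave open how this read-out would respond to a chloro group, a methoxy group or an amine on the aromatic ring. They also leave open what a longer chain between the shared core and the carbamate would do.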